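This account rests on a few compounds, and the source may have more. Where it says the series, first, only, none or still open, it means among the compounds named here.

Compound 2 `Cc1nc(C)n(CC(=O)N2CCN(c3sc(C(F)(F)F)nc3-c3nc4ccc(C5CCOCC5)cc4[nH]3)C[C@H]2C)n1` gives the lower of the two numbers recorded so far in a functional assay on Venous blood for antagonist activity at C-X-C chemokine receptor type 3 (Homo sapiens), read by flow cytometry, with a stated time of 30 min, in the presence of a further agent that is not named here; a lower number here means a stronger inhibitor, a higher number a weaker inhibitor: compound 2 gives 123 nM, whereas compound 1 `COC1CCN(CC(=O)N2CCN(c3sc(C(F)(F)F)nc3-c3nc4ccccc4[nH]3)C[C@H]2C)C1` gives 3380 nM, a gap well beyond the scatter. Compound 3 `Cc1nc(C)n(CC(=O)N2CCN(c3sc(C(F)(F)F)nc3-c3nc4ccc(S(C)(=O)=O)cc4[nH]3)C[C@H]2C)n1` differs from compound 2 in one place: methylsulfonyl in place of oxan-4-yl on an aromatic carbon. Among the compounds with values here, no measured pair shows this change, so its effect is unknown; the expected step of a 1.8-fold higher number from compound 2 to compound 3 (0.25 log units; within the scatter) is small, perhaps a slight weakening, and may lie within the scatter. On that basis compound 3 is estimated at 220 nM, within a range of 60 nM to 800 nM.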

Compound 3, half-maximal inhibitory concentration: 959 nM
Beside the measured number, compound 3's estimate is 4.4-fold (0.64 log units) below it; the whole stated range lies below it.
By their numbers in this assay, from the lowest: compound 2; then compound 3; then compound 1.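

In this assay, within the data shown here, the exchange of oxan-4-yl for methylsulfonyl on this aromatic carbon gives a 7.8-fold higher number from compound 2 to compound 3 (0.89 log units; beyond the scatter), the first change at a single place to be read, and it shows that the group here bears on the number. Oxan-4-yl gives the stronger inhibitor of this pair. No measurement available here bears on why the number rises. Compound 1 differs from both in more than one place, so the effect of a bare aromatic carbon cannot be read. From the compounds shown here alone, whether a methyl, an amine or a carboxylic acid here would match oxan-4-yl remains open.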